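Swapping methoxy for fluoro on the core of compound 1

The source may hold more compounds than are shown below. What is called first, only, known or untested is meant among the compounds shown, and "the series" means these compounds.

Compound 1 `COc1ccc2sc(NC(=O)c3cc(=O)c4ccccc4o3)nc2c1`: 380 nM
Compound 2 `O=C(Nc1nc(-c2ccc(F)cc2)cs1)c1cc(=O)c2ccccc2o1`: 520 nM

Both values come from a functional assay on A549 cells (Homo sapiens) for antiproliferative activity, read by CCK-8 assay, with a stated time of 48 h; on this read-out lower numbers stand for stronger inhibition and higher numbers for weaker inhibition. Compound 1 stands level with compound 2, since the two numbers lie within the usual scatter of each other and cannot rank them. Among the measured compounds shown here, the two compounds also differ in more than one place, so no measured step shows what a single change does here.

Compound 3 `O=C(Nc1nc2cc(F)ccc2s1)c1cc(=O)c2ccccc2o1` keeps the core of compound 1 and changes one group: fluoro in place of methoxy on an aromatic carbon. For the measured compounds named here, the only hint available is compound 2, which has a fluoro group and no methoxy on a different framework and still gives 520 nM. A large loss therefore seems unlikely, though this is weak evidence. The expected step is a 1.4-fold higher number from compound 1 to compound 3 (0.16 log units; within the scatter), a slightly higher number and nothing clearly beyond the scatter. In this assay the estimate for compound 3 is 550 nM, with an expected range from 180 nM to 1700 nM.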

Compound 3, half-maximal inhibitory concentration: 440 nM
Compound 3: middle estimate off by 1.3-fold (0.10 log units), on the high side; the measured number falls inside the stated range.
By their numbers in this assay, from the lowest: compounds 1, 3 and 2 (each within the scatter of the next).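

Among the compounds shown here, replacing methoxy with fluoro on this aromatic carbon is the first single change that can be read on its own, and in this assay it gives a 1.2-fold higher number from compound 1 to compound 3 (0.06 log units; within the scatter) for the shared core. Compounds 1 and 2 differed in more than one place, so they could not show this. The result shows that, in this cell assay, the methoxy group, with its two heavy atoms and one hydrogen-bond acceptor, can give way to the single fluorine atom, which counts no acceptor, without a change that can be told from the scatter; no measurement at hand explains why the two groups read alike.

From the compounds shown here alone, whether this position responds to anything other than these two small groups remains open, for instance an amine, a carboxylic acid or a longer chain such as butoxy, any of which might move the number clearly beyond the scatter. For the compounds shown here, also open is whether the same swap would read the same way on a different framework, such as the one carried by compound 2.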